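A few compounds are considered here, and "the series" means these few. Any claim that something is new, unique, unknown or untested is made for them only; others in the source may bear on it.

Working notes on the series. The three measured compounds share one core and differ only in the aryl group on a saturated ring carbon. Compound 1 `COc1ccc(OC)c(C2OC(c3cc(OC)c(OC)c(OC)c3)=NN2C(C)=O)c1` gives 37.2% in a functional assay on PC-3 cells (Homo sapiens) for antiproliferative activity, read by MTT assay, tested at 1 uM; on this read-out lower numbers stand for a weaker effect and higher numbers for a stronger effect at the one concentration tested. Compound 2 `COc1cc(C2=NN(C(C)=O)C(c3ccccc3C(F)(F)F)O2)cc(OC)c1OC` gives -11% in this assay. Compound 3 `COc1cc(C2=NN(C(C)=O)C(c3ccc(Cl)c(Cl)c3)O2)cc(OC)c1OC` gives 28.1% in this assay, the second highest of the three numbers; it sits within the scatter of compound 1 and well above compound 2.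

The next compound, compound 4 `COc1cc(C2=NN(C(C)=O)C(c3cccc(F)c3)O2)cc(OC)c1OC`, carries the change (3-fluorophenyl in place of 3,4-dichlorophenyl on a saturated ring carbon). All three known steps bear on it, since each swaps the aryl group at this position: a number 9.1 percentage points lower from compound 1 to compound 3 (within the scatter) and the two large steps of a number 48.2 percentage points lower from compound 1 to compound 2 (beyond the scatter) and a number 39.1 percentage points higher from compound 2 to compound 3 (beyond the scatter). Aryl swaps here can thus be small or large, and the data hold no prior mono-fluoro example. Compound 4 is expected to run somewhat below compound 3, with the step of a number 8.1 percentage points lower from compound 3 to compound 4 (within the scatter) judged likely to stay near the scatter. The estimate for compound 4 in this assay is 20%, ranging from 0% to 40%.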

Compound 4, a percentage reported as inhibition, at one concentration (the size of the read-out at that concentration, not a potency): 16.5%
For compound 4 the middle estimate is 3.5 percentage points above the measured one; measured number inside the range.
By their numbers in this assay, from the lowest: compound 2; then compound 4; then compounds 3 and 1 (each within the scatter of the next).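

In this assay, a smaller aryl change at this saturated ring carbon also moves the read-out beyond the scatter: a number 11.6 percentage points lower from compound 3 to compound 4 (beyond the scatter), with 3-fluorophenyl replacing 3,4-dichlorophenyl. Compound 4 also stands apart from both ends of the series, with a number 27.5 percentage points higher from compound 2 to compound 4 (beyond the scatter) and a number 20.7 percentage points lower from compound 1 to compound 4 (beyond the scatter), so the position now gives three separated levels: compound 2, compound 4, and compounds 1 and 3 together. Nothing available explains these differences between the aryl groups.

The step from compound 3 to compound 4 alters both halogen substituents at once, so the shares of the lost 4-chloro group and of fluorine in place of chlorine stay unresolved; 3-chlorophenyl would separate them. Also open, on these data alone, is how an aryl group carrying an amine or a carboxylic acid would behave on this carbon.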